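Pyrrolidine in place of methylamino on the dithiocarbamate

This account rests on a few compounds, and the source may have more. Where it says the series, first, only, none or still open, it means among the compounds named here.

Compound 1 `CCNC(=S)SCC1=CCOC1=O` and compound 2 `CNC(=S)SCC1=CCOC1=O` share a core and differ only at the nitrogen substituent. In a functional assay on PC-3 cells (Homo sapiens) for antiproliferative activity, read by MTT assay, with a stated time of 72 h (a lower number here means a stronger inhibitor, a higher number a weaker inhibitor), compound 1 gives 30600 nM, and compound 2 gives 76500 nM. Compound 2 thus has the highest number of the two, its nearest neighbour being compound 1 with a 2.5-fold higher number from compound 1 to compound 2 (0.40 log units; beyond the scatter), a change of hydrogen in place of methyl on a saturated chain carbon bound to an amide-type nitrogen.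

Compound 3 `O=C1OCC=C1CSC(=S)N1CCCC1` carries pyrrolidin-1-yl in place of methylamino on a thiocarbonyl carbon. Among the compounds with values here, the only measured step that bears on this is the one from compound 1 to compound 2, where removing carbon from the nitrogen raised the number modestly; adding carbon back, in ring form, is expected to run the other way by a similar or somewhat larger amount. The step of a 3.1-fold lower number from compound 2 to compound 3 (0.49 log units; beyond the scatter) is therefore expected to be a lower number. Compound 3 is estimated at 25000 nM in this assay, within 8000 nM to 80000 nM.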

Compound 3, half-maximal inhibitory concentration: 114000 nM
Beside the measured number, compound 3's estimate is 4.6-fold (0.66 log units) below it; measured number above the stated range.
By their numbers in this assay, from the lowest: compound 1; then compounds 2 and 3 (each within the scatter of the next).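

In this assay, the ring on the thiocarbonyl carbon does not continue the trend from methylamino to ethylamino: a 1.5-fold higher number from compound 2 to compound 3 (0.17 log units; within the scatter), so pyrrolidin-1-yl and methylamino cannot be told apart here. Against ethylamino, the same ring gives a 3.7-fold higher number from compound 1 to compound 3 (0.57 log units; beyond the scatter), which leaves compound 1 as the only one of the three set apart, and compound 3 goes against any reading in which more carbon on the nitrogen brings a lower number. Nothing at hand bears on why the ring gives this result.

Still open, from the compounds shown here alone, is whether the ring itself or the loss of the hydrogen-bond donor separates compound 3 from compound 1; an open-chain diethylamino group would help divide the two. A longer chain such as propylamino, and a larger ring such as piperidin-1-yl, would show how far either trend extends.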